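This account rests on a few compounds, and the source may have more. Where it says the series, first, only, none or still open, it means among the compounds named here.

Measured compounds:
compound 1 `CCC(=O)N(Cc1ccc(OC)c(O)c1)c1cc(OC)c(OC)c(OC)c1`: 50 nM
compound 2 `COc1ccc(CNc2cc(OC)c(OC)c(OC)c2)cc1`: 11400 nM
compound 3 `COc1cc(NCc2cccc(O)c2)cc(OC)c1OC`: 57600 nM

In a functional assay on MGC-803 cells (Homo sapiens) for inhibition, read by MTT assay, with a stated time of 48 h (on this read-out lower numbers stand for stronger inhibition and higher numbers for weaker inhibition), compound 1 gives the lowest of the three numbers. Compound 2 gives a far higher number, and compound 3 a higher one still; both gaps lie well beyond the usual scatter, so compound 1 is the most potent of the three in this assay. Compound 4 `COc1ccc(CN(C(=O)CCCCCl)c2cc(OC)c(OC)c(OC)c2)cc1O` has not yet been measured. It differs from compound 1 in one place: 2-chloroethyl in place of hydrogen on a saturated chain carbon, two bonds along the chain from a carbonyl carbon. Among the compounds with values here, no measured pair shows what lengthening this chain does, so the expectation rests on compound 1 alone, which holds this assay's best number at 50 nM. A change on a saturated chain, away from the rings of the core, is expected to move the number only a little, most likely toward a slightly weaker inhibition, and the step of a 1.8-fold higher number from compound 1 to compound 4 (0.26 log units; within the scatter) is estimated to stay close to the scatter. Compound 4 is therefore expected to give about 90 nM in this assay, with a range from 20 nM to 400 nM.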

Compound 4, half-maximal inhibitory concentration: 540 nM
Compound 4: the middle estimate sits 6.0-fold (0.78 log units) below what was measured; measured number above the stated range.
By their numbers in this assay, from the lowest: compound 1; then compound 4; then compound 2; then compound 3.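

In this assay, the saturated chain carbon two bonds along the chain from a carbonyl carbon turns out to be sensitive to substitution: 2-chloroethyl in place of hydrogen there gives an 11-fold higher number from compound 1 to compound 4 (1.03 log units; beyond the scatter), a step beyond the usual scatter. Within the data shown here, this is the first direct reading of the position, and it shows that, of these two acyl chains, the propanoyl of compound 1 goes with the stronger inhibition. Nothing at hand bears on why the number rises with this change.

The compounds shown leave open whether the higher number follows the added chain length or the chlorine, since the step changes both at once. On these data alone, how a pentanoyl chain without chlorine, or a shorter acetyl, would read in this assay also remains open.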